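Buffer half-life across three small aryl variants

The source may hold more compounds than are shown below. What is called first, only, known or untested is meant among the compounds shown, and "the series" means these compounds.

compound 1 `C=Cc1cc(C(F)(F)F)cc(C(F)(F)F)c1`: > 50 h (a limit)
compound 2 `FC(F)(F)c1cc(C2CO2)cc(C(F)(F)F)c1`: > 50 h (a limit)

In an ADME assay for pharmacokinetics, read by LC-MS, in phosphate buffer, with a stated time of 72 h, at pH 7.4, tested at 250 uM (a lower number here means that the compound disappears faster, a higher number that the compound lasts longer), compound 1 returns only the limit of the assay, not a number. Compound 2 likewise returns only the limit. The step that the two limits leave unreadable from compound 1 to compound 2 is therefore unreadable, both values sitting at the limit of > 50 h in this assay, at which 2 of the 2 values shown sit. Compound 2 thus stands at the top of what this assay can report, with no number inside the measurable range.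

Compound 3 `FC(F)(F)c1cc(S)cc(C(F)(F)F)c1` differs from compound 2 by sulfanyl in place of oxiran-2-yl on an aromatic carbon. Among the measured compounds shown here, no measured step involves a sulfanyl group, and the single step measured in this assay gives no readable size, so no size or direction for the change to compound 3 can be drawn from the measured compounds. In this assay compound 3 is estimated at 35 h, with a range from 8 h to 80 h. This estimate means an expected step of an at least 1.4-fold lower number from compound 2 to compound 3 (0.15 log units; that floor lies within the scatter), which may again end at the limit.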

Compound 3, half-life: 33 h
Compound 3: the middle estimate sits 1.1-fold (0.03 log units) above what was measured; low and high end bracket the measured number.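

In this assay compound 3 gives 33 h, the first number inside the measurable range for a group at this place, meta to two trifluoromethyl groups. Sulfanyl in place of oxiran-2-yl gives an at least 1.5-fold lower number from compound 2 to compound 3 (0.18 log units; that floor lies within the scatter), and sulfanyl in place of vinyl gives an at least 1.5-fold lower number from compound 1 to compound 3 (0.18 log units; that floor lies within the scatter), so a change at this place can bring the read-out off the limit, although neither printed floor clears the scatter. The values of compound 1 and compound 2 are both limits, and the step between them cannot be read: the limit of > 50 h in this assay, at which 2 of the 3 values shown sit.

As far as these compounds go, how far compound 1 and compound 2 lie past their limit stays open, and with it the true size of both steps. Also open, from the compounds shown here alone, is whether an amine or a carboxylic acid at this place would give a number inside the range.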